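The source may hold more compounds than are shown below. What is called first, only, known or untested is meant among the compounds shown, and "the series" means these compounds.

Three triazoles sharing one core have been measured in a functional assay on PC-12 cells (Rattus norvegicus) for cytotoxicity, read by MTT assay, with stated times of 2 h and 24 h, tested at 5 uM; on this read-out higher numbers stand for a stronger effect at the one concentration tested and lower numbers for a weaker effect. Compound 1 `Oc1cc(C(F)(F)F)ccc1-c1nc(-c2ccccc2O)n(-c2ccccc2C(F)(F)F)n1` gives 80%, compound 2 `Oc1cc(C(F)(F)F)ccc1-c1nc(-c2ccccc2O)n(-c2cccc(F)c2)n1` gives 87.7%, and compound 3 `Cc1ccc(-n2nc(-c3ccc(C(F)(F)F)cc3O)nc2-c2ccccc2O)c(C)c1` gives 93.3%. On these numbers compound 3 is separated beyond the scatter only from compound 1, by a number 13.3 percentage points higher from compound 1 to compound 3 (beyond the scatter); its distance from compound 2, a number 5.6 percentage points higher from compound 2 to compound 3 (within the scatter), is within the scatter, as is the step of a number 7.7 percentage points higher from compound 1 to compound 2 (within the scatter).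

Compound 4 `Oc1cc(C(F)(F)F)ccc1-c1nc(-c2ccccc2O)n(-c2cc(F)cc(F)c2)n1` is not yet measured. It differs from compound 3 in one place: 3,5-difluorophenyl in place of 2,4-dimethylphenyl on an aromatic nitrogen. Within the data shown here, the steps that bear on this all involve the group on the aromatic nitrogen. A fluorophenyl already sits there in compound 2, and a number 5.6 percentage points higher from compound 2 to compound 3 (within the scatter) shows that swapping it for 2,4-dimethylphenyl moved the read-out within the scatter; a number 7.7 percentage points higher from compound 1 to compound 2 (within the scatter) was likewise within the scatter. No step beyond the scatter is therefore expected in this assay , and a small downward drift at most. Compound 4 is estimated at 88%, between 78% and 96%, which is an expected step of a number 5.3 percentage points lower from compound 3 to compound 4 (within the scatter).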

Compound 4, a percentage reported as activity, at one concentration (the size of the read-out at that concentration, not a potency): 100%
For compound 4 the middle estimate is 12 percentage points below the measured one, outside the stated range (above it).
By their numbers in this assay, from the lowest: compounds 1, 2, 3 and 4 (each within the scatter of the next, the first and the last beyond it).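

In this assay, among these compounds, a fluoro in place of hydrogen on an aromatic carbon of the group on the aromatic nitrogen separates two compounds beyond the scatter (a number 12.3 percentage points higher from compound 2 to compound 4 (beyond the scatter)), which no step between compound 2 and another compound had done before. The exchange of 2,4-dimethylphenyl for 3,5-difluorophenyl does not separate its pair (a number 6.7 percentage points higher from compound 3 to compound 4 (within the scatter)), so these two quite differently substituted phenyl groups are not told apart at this position. Against 2-(trifluoromethyl)phenyl, 3,5-difluorophenyl is separated beyond the scatter (a number 20 percentage points higher from compound 1 to compound 4 (beyond the scatter)), making it the second group after 2,4-dimethylphenyl to stand clear of that group.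

How an amine or a carboxylic acid on this phenyl ring, or a saturated ring in place of it, would read remains open, as does any ranking of these compounds at other concentrations. The compounds shown come with no measurement that accounts for these steps.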